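The compounds below may be only part of what the source reports. "The series", "measured", "known", "first", "only" and "open" are said of these compounds alone.

In an ADME assay on K562 cells (Homo sapiens) for cytotoxicity, with a stated time of 72 h (a higher number here means a weaker inhibitor, a lower number a stronger inhibitor), compound 1 `COc1ccc(CNc2ncnc3c2ncn3C2CCCO2)c(OC)c1` gives > 100000 nM, which is a limit of the assay. Compound 2 `COc1ccc(OC)c(CNc2ncnc3c2ncn3C2CCCO2)c1` gives > 50000 nM, likewise a limit, so its standing is known only as a limit and not as a number. Compound 3 `COc1cc(OC)c(OC)cc1CNc1ncnc2c1ncn2C1CCCO1` differs from compound 2 by methoxy in place of hydrogen on an aromatic carbon, with methoxy in place of hydrogen on an aromatic carbon. No change beyond the scatter, in either direction, is expected in this assay, and the estimated step is a step that the limit leaves unreadable from compound 2 to compound 3. For compound 3 the expected value is 70000 nM, with an estimated range of 30000 nM to 150000 nM.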

Compound 3, half-maximal inhibitory concentration: > 100000 nM
Compound 3: no number, only a limit; the forecaster's own chance of this, stated with the estimate: 75%; middle value at least 1.4-fold (0.15 log units) from the limit.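

Compound 3 gives > 100000 nM in this assay, which is a limit. Within the data shown here, compound 1 and compound 2 also give limits, so no step from either to compound 3 can be read. The compounds shown leave open the actual potency of all three.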